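The source may hold more compounds than are shown below. What is called first, only, known or untested is meant among the compounds shown, and "the series" means these compounds.

- compound 1 `NS(=O)(=O)c1ccc(N2N=C(c3ccc(Oc4ccccc4)cc3)CC2c2cccc(F)c2)cc1` gives 28000 nM
- compound 2 `Cc1ccccc1C1CC(c2ccc(Oc3ccccc3)cc2)=NN1c1ccc(S(N)(=O)=O)cc1` gives 90000 nM

In an ADME assay on Vero 76 cells (Chlorocebus sabaeus) for cytotoxicity, read by MTT assay, with a stated time of 96 h (a lower number here means that less compound is tolerated, a higher number that more compound is tolerated), compound 2 holds the higher of the two numbers. Compound 3 `NS(=O)(=O)c1ccc(N2N=C(c3ccc(Oc4ccccc4)cc3)CC2c2ccc(Cl)cc2)cc1` has 4-chlorophenyl in place of 2-methylphenyl on a saturated ring carbon. Going by the values given here, the only measured step at this place is modest: a 3.2-fold higher number from compound 1 to compound 2 (0.51 log units; beyond the scatter). With 3-fluorophenyl there, compound 1 stays the nearest guide, although a single step gives thin support. A step of similar size toward a lower number is therefore expected: a 2.6-fold lower number from compound 2 to compound 3 (0.41 log units; beyond the scatter). The estimate for compound 3 is 35000 nM, with an expected range of 12000 nM to 90000 nM.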

Compound 3, half-maximal cytotoxic concentration: 88000 nM
Compound 3: the middle estimate sits 2.5-fold (0.40 log units) below what was measured; low and high end bracket the measured number.
By their numbers in this assay, from the lowest: compound 1; then compounds 3 and 2 (each within the scatter of the next).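

In this assay, 4-chlorophenyl and 2-methylphenyl on the saturated ring carbon cannot be told apart: the step is a 1.0-fold lower number from compound 2 to compound 3 (0.01 log units; within the scatter). Replacing 3-fluorophenyl with 4-chlorophenyl gives a 3.1-fold higher number from compound 1 to compound 3 (0.50 log units; beyond the scatter), so compound 1 now differs from two compounds, not one, and the first step no longer stands alone. No measurement here bears on why these numbers fall as they do. On these data alone, whether the separation of compound 1 follows the fluorine or the place of the substituent on the phenyl stays open, since both change together. As far as these compounds go, how an amine or a carboxylic acid on this phenyl would read also stays open.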